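The source may report more compounds than this note shows. Statements on the series, on what has been measured and on what is new or still open speak of the compounds shown alone.

Working notes on the series. In an assay on isolated protein for binding affinity to Discoidin domain-containing receptor 2 (Homo sapiens), read by thermal shift assay, tested at 10 uM (a higher number here means that the compound stabilises the target more against heat, a lower number that the compound stabilises the target less), compound 1 `CCCNC(=O)[C@H](CCC1CCCCC1)NC(=O)c1ccc(CNC(=O)c2cnn(-c3ccccc3)c2N)cc1` gives 3.8 degrees C. Compound 2 `CC(NC(=O)c1cc(-c2ccccc2)n[nH]1)c1ccc(C(=O)N[C@@H](CCC2CCCCC2)C(=O)NC2CCCN(S(C)(=O)=O)C2)cc1` gives in this assay a value of 1.7 degrees C, and compound 3 `CC(NC(=O)c1cc(-c2ccccc2)n[nH]1)c1ccc(C(=O)N[C@@H](CCC2CCCCC2)C(=O)N[C@H]2CCCN(S(C)(=O)=O)C2)cc1` gives 1.5 degrees C. Compound 3 thus stands lowest of the three numbers in this assay; compound 2 sits nearest, by a margin within the scatter, and compound 1 furthest, by a margin beyond the scatter.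

Compound 4 `CC(NC(=O)c1cc(-c2ccccc2)n[nH]1)c1ccc(C(=O)N[C@@H](CCC2CCCCC2)C(=O)N[C@@H]2CCCN(S(C)(=O)=O)C2)cc1` differs from compound 3 only in this way: the two compounds have the same atoms and bonds; at least one stereo element is drawn with a configuration in one of them and without one in the other: 1 of 3 stereo elements differ; a stereocentre at a saturated ring carbon is drawn S in compound 3 and R in compound 4. Going by the values given here, the one measured step that bears on this change is a number 0.20 degrees C lower from compound 2 to compound 3 (within the scatter), a difference that counts as no change; this pair is informative because of the fact that one of compounds 2 and 3 is drawn with a defined configuration and the other without, at the place where they differ, the ring carbon being drawn without a configuration in compound 2 and as S in compound 3. On that basis no step beyond the scatter is expected in this assay in either direction. The step expected from compound 3 to compound 4 is a number 0.30 degrees C higher from compound 3 to compound 4 (within the scatter). For compound 4 the estimate in this assay is 1.8 degrees C, with a range from 0.6 degrees C to 3 degrees C.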

Compound 4, shift of the target's melting temperature: 1.9 degrees C
For compound 4 the middle estimate is 0.10 degrees C below the measured one; the measured number falls inside the stated range.
By their numbers in this assay, from the lowest: compounds 3, 2 and 4 (each within the scatter of the next); then compound 1.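

The two defined configurations at the saturated ring carbon can now be set side by side, and in this assay the S to R change gives a number 0.40 degrees C higher from compound 3 to compound 4 (within the scatter). This series therefore shows no measurable dependence on the configuration at this ring carbon, a result the earlier step could not give, as it compared a defined centre with an undefined one. The step of a number 0.20 degrees C higher from compound 2 to compound 4 (within the scatter) agrees with this, but it says less about the R configuration taken alone, and the reason for caution lies in how the pair is drawn: the fact that one of compounds 2 and 4 is drawn with a defined configuration and the other without, at the place where they differ

The compounds shown leave open whether this centre stays without effect when the methylsulfonyl group gives way to an acetyl group or a carboxylic acid. They also leave open whether a free amine in that place would shift the melting temperature at all.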